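The compounds below may be only part of what the source reports. "The series", "measured", "known", "first", "only" and "open" are said of these compounds alone.

Measured compounds:
compound 1 `N#Cc1cnc(NCc2cnccc2C(F)(F)F)cc1NC[C@H]1C[C@@H](O)C1`, 300 nM in an assay on isolated protein for inhibition of protein kinase C theta type (Homo sapiens), read by TR-FRET, with a stated time of 2 h; on this read-out higher numbers stand for weaker inhibition and lower numbers for stronger inhibition
compound 2 `CC1(C)C[C@H](Nc2cc(NCc3cnccc3C(F)(F)F)ncc2C#N)CC(C)(C)[C@@H]1O`, 12 nM in this assay

Going by the values given here, compound 1 stands at the highest number of the two measured in this assay; its only neighbour, compound 2, sits at a lower number, and the gap between them is well beyond the scatter. Among the compounds with values here, no single-point step between measured compounds is available, so the pair tells only that a dimethyl-substituted carbon ring joined to the amine nitrogen goes with a much lower number than the (3-hydroxycyclobutyl)methyl chain of compound 1.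

Compound 3 `CC1(C)[C@@H](Nc2cc(NCc3cnccc3C(F)(F)F)ncc2C#N)C[C@@H]1C(N)=O` is not yet measured. Relative to compound 1 the change is 3-carbamoyl-2,2-dimethylcyclobutyl in place of (3-hydroxycyclobutyl)methyl on a nitrogen on an aromatic ring. The entering 3-carbamoyl-2,2-dimethylcyclobutyl shares with compound 2 a dimethyl-substituted ring on the amine nitrogen, while the carbamoyl takes the place of the hydroxyl as the single donor and acceptor.

Given the much lower number of compound 2, compound 3 is expected to move toward stronger inhibition, and the step of a 6.7-fold lower number from compound 1 to compound 3 (0.82 log units; beyond the scatter) is estimated as a clear drop beyond the scatter, though not necessarily the full distance to compound 2. For compound 3 in this assay the estimate is 45 nM, within 12 nM to 170 nM.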

Compound 3, half-maximal inhibitory concentration: 1100 nM
Compound 3: the middle estimate sits 24-fold (1.39 log units) below what was measured; measured number above the stated range.
By their numbers in this assay, from the lowest: compound 2; then compound 1; then compound 3.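

In this assay the group on the nitrogen on the aromatic ring can also raise the number: 3-carbamoyl-2,2-dimethylcyclobutyl in place of (3-hydroxycyclobutyl)methyl gives a 3.7-fold higher number from compound 1 to compound 3 (0.56 log units; beyond the scatter), a modest step beyond the scatter. A dimethyl-substituted carbon ring at this position therefore does not by itself go with a lower number, since compound 2 gives 12 nM while compound 3 gives 1100 nM and the earlier link between such a ring and a low number now rests on compound 2 alone. No measurement shown here accounts for the step.

The step from compound 1 bundles several differences, so the share of the loss of the methylene link to the nitrogen, of the two methyl groups and of carbamoyl in place of hydroxyl remains unresolved. A 3-hydroxy-2,2-dimethylcyclobutyl group, or a carboxylic acid or primary amine in place of the carbamoyl on the same ring, would help to separate these contributions.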